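Replacing the Propyl Amide of Compound 3 with an Ethoxycarbonyl

A few compounds are considered here, and "the series" means these few. Any claim that something is new, unique, unknown or untested is made for them only; others in the source may bear on it.

Three analogues built on one shared core have been measured in a functional assay on HUVEC cells (Homo sapiens) for inhibition, tested at 10 ug/mL; on this read-out lower numbers stand for a weaker effect and higher numbers for a stronger effect at the one concentration tested. Compound 1 `COc1cc(/C=C/C(=O)c2cccc(NC(=O)c3c(Cl)cccc3Cl)c2)ccc1O` gives 99% in this assay. Compound 2 `COc1cc(/C=C/C(=O)c2cccc(NC(=O)C(C)C)c2)ccc1O` gives 56%. Compound 3 `CCCC(=O)Nc1cccc(C(=O)/C=C/c2ccc(O)c(OC)c2)c1` gives 87%, which places it second highest of the three numbers: the gap to the top is a number 12 percentage points lower from compound 1 to compound 3 (beyond the scatter), while the gap to the bottom is a number 31 percentage points higher from compound 2 to compound 3 (beyond the scatter). The untested compound 4 `CCOC(=O)C(=O)Nc1cccc(C(=O)/C=C/c2ccc(O)c(OC)c2)c1` differs from compound 3 at the amide end only: ethoxycarbonyl in place of propyl on a carbonyl carbon.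

Going by the values given here, two measured steps bear on this position, both at the same carbonyl carbon. The branched substituent cost a great deal, a number 43 percentage points lower from compound 1 to compound 2 (beyond the scatter), whereas the straight chain recovered most of that loss, a number 31 percentage points higher from compound 2 to compound 3 (beyond the scatter). Among the compounds with values here, none of the measured compounds carries an ethoxycarbonyl here, so the step from propyl to ethoxycarbonyl has no direct precedent, and the measured steps show only that this position can move the read-out strongly in either direction. For compound 4 the estimated step is a number 12 percentage points lower from compound 3 to compound 4 (beyond the scatter), a modest decrease that is close to the scatter. Compound 4 is expected to give about 75%, with a range from 45% to 95%.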

Compound 4, a percentage reported as inhibition, at one concentration (the size of the read-out at that concentration, not a potency): 66%
Estimate against measurement, compound 4: 9 percentage points above; the range from low to high includes it.
By their numbers in this assay, from the lowest: compounds 2 and 4 (each within the scatter of the next); then compound 3; then compound 1.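

In this assay, going by these compounds alone, ethoxycarbonyl is the first group on this carbonyl carbon to carry oxygen atoms, and it does not keep the level reached with propyl: the change gives a number 21 percentage points lower from compound 3 to compound 4 (beyond the scatter) and so shows that an unbranched group here does not in itself secure a high number. The comparison with the branched group gives a number 10 percentage points higher from compound 2 to compound 4 (within the scatter), which places compound 4 alongside compound 2, while the comparison with the aromatic group gives a number 33 percentage points lower from compound 1 to compound 4 (beyond the scatter), so 2,6-dichlorophenyl remains well clear of ethoxycarbonyl as well. No evidence given here accounts for the loss on going from propyl to ethoxycarbonyl.

The compounds shown leave open whether the loss belongs to the added carbonyl, to the ethyl ester end or to the greater length of the group, and a pentyl chain or a simple methoxymethyl group at this place would help to separate these readings. They also leave open how a carboxylic acid or a primary amide in place of the ethoxy end of compound 4 would read out on the same scale.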